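The source may hold more compounds than are shown below. What is called first, only, known or untested is meant among the compounds shown, and "the series" means these compounds.

Measured so far in a functional assay on MCF7 cells (Homo sapiens) for inhibition, read by CCK-8 assay, with a stated time of 48 h; on this read-out lower numbers stand for stronger inhibition and higher numbers for weaker inhibition:
Compound 1 `COc1cc(-c2ccnc3cc(-c4ccccc4)nn23)cc(OC)c1OC`: 254 nM
Compound 2 `COc1cc(-c2ccnc3cc(-c4ccc(N(C)C)cc4)nn23)cc(OC)c1OC`: 44 nM
Compound 3 `COc1ccc(-c2cc3nccc(-c4cc(OC)c(OC)c(OC)c4)n3n2)cc1`: 125 nM

Compound 3 sits in the middle of this set, with compound 1 giving the highest number and compound 2 the lowest. The next compound, compound 4 `CCOC(=O)c1ccc(-c2cc3nccc(-c4cc(OC)c(OC)c(OC)c4)n3n2)cc1`, keeps the shared core but carries ethoxycarbonyl in place of methoxy on an aromatic carbon, para to a large group (ethoxycarbonyl in place of methoxy on an aromatic carbon).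

For the measured compounds named here, three measured steps bear on this place: a 2.0-fold lower number from compound 1 to compound 3 (0.31 log units; beyond the scatter) for methoxy in place of hydrogen, a 5.8-fold lower number from compound 1 to compound 2 (0.76 log units; beyond the scatter) for dimethylamino in place of hydrogen, and a 2.8-fold higher number from compound 2 to compound 3 (0.45 log units; beyond the scatter) for methoxy in place of dimethylamino. All three are modest. Going by the values given here, no measured compound carries ethoxycarbonyl, so the direction is uncertain. Both groups tested here gave lower numbers than hydrogen, but that need not hold for a very different group, so a modest rise towards compound 1 at 254 nM is expected. The expected change is a 1.8-fold higher number from compound 3 to compound 4 (0.25 log units; within the scatter). Compound 4 is estimated at 220 nM, with an expected range of 70 nM to 700 nM.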

Compound 4, half-maximal inhibitory concentration: > 10000 nM
Compound 4 gave a limit, no number; the forecaster's own chance of this, stated with the estimate: 4%; middle value at least 45-fold (1.65 log units) from the limit.
By their numbers in this assay, from the lowest: compound 2; then compound 3; then compound 1. At a limit, above all of these: compound 4.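

Compound 4 gives only a limit in this read-out, not a number: the limit of > 10000 nM in this assay, at which 1 of the 4 values shown sits.

The earlier compounds shown here, with hydrogen, methoxy or dimethylamino at this place, differed only modestly, whereas ethoxycarbonyl brings an at least 80-fold higher number from compound 3 to compound 4 (1.90 log units; beyond the scatter), an at least 39-fold higher number from compound 1 to compound 4 (1.59 log units; beyond the scatter) and an at least 220-fold higher number from compound 2 to compound 4 (2.35 log units; beyond the scatter). This position therefore does not accept every group: ethoxycarbonyl is the first group shown here that does worse than plain hydrogen, and by a large step rather than the modest rise that the earlier steps suggested.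

With a single ester shown, it remains open whether the drop belongs to the ester as a whole or to its ethyl part, which a methyl ester, a carboxylic acid or an amide at this place could help to separate. Going by these compounds, it also remains open whether a smaller amine would match the dimethylamino group of compound 2.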